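Carbamate side chain and growth inhibition in the selenocyanate series

This account rests on a few compounds, and the source may have more. Where it says the series, first, only, none or still open, it means among the compounds named here.

compound 1 `CC(C)COC(=O)Nc1ccc([Se]C#N)cc1`: in an ADME assay on BEAS-2B cells (Homo sapiens) for cytotoxicity, read by MTT assay, with a stated time of 72 h (on this read-out higher numbers stand for weaker inhibition of growth and lower numbers for stronger inhibition of growth), compound 1 gives 26900 nM
compound 2 `C=CCOC(=O)Nc1ccc([Se]C#N)cc1`: compound 2 gives 21400 nM
compound 3 `N#C[Se]c1ccc(NC(=O)Oc2ccccc2)cc1`: compound 3 gives 8900 nM

In this assay compound 2 stands second highest of the three numbers; the step of a 1.3-fold lower number from compound 1 to compound 2 (0.10 log units; within the scatter) lies within the scatter, while the step of a 2.4-fold lower number from compound 2 to compound 3 (0.38 log units; beyond the scatter) lies beyond it. Compound 4 `N#C[Se]c1ccc(NC(=O)OCc2ccccc2)cc1` differs from compound 2 by phenyl in place of vinyl on a saturated chain carbon bound to an oxygen next to a carbonyl group. Among the measured compounds shown here, no measured step places phenyl on that saturated chain carbon. The nearest comparisons are the steps to the phenyl carbamate, a 2.4-fold lower number from compound 2 to compound 3 (0.38 log units; beyond the scatter) and a 3.0-fold lower number from compound 1 to compound 3 (0.48 log units; beyond the scatter), both modest lowerings, whereas the chain swap a 1.3-fold lower number from compound 1 to compound 2 (0.10 log units; within the scatter) stayed within the scatter. A modest lowering is therefore expected for compound 4, a 1.5-fold lower number from compound 2 to compound 4 (0.18 log units; within the scatter), somewhat smaller than the steps to compound 3 since the phenyl of compound 4 sits on the saturated chain carbon rather than on the oxygen. Compound 4 is estimated at 14000 nM, with a range of 7000 nM to 28000 nM.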

Compound 4, concentration for 50% growth inhibition: 100 nM
Compound 4: middle estimate off by 140-fold (2.15 log units), on the high side; the measured number lies below the stated range.
By their numbers in this assay, from the lowest: compound 4; then compound 3; then compounds 2 and 1 (each within the scatter of the next).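

Phenyl on a saturated chain carbon bound to an oxygen next to a carbonyl group gives, in this assay, a 210-fold lower number from compound 2 to compound 4 (2.33 log units; beyond the scatter) and a 270-fold lower number from compound 1 to compound 4 (2.43 log units; beyond the scatter) as large steps, so this position is far more sensitive than the earlier compounds showed. Phenyl on the oxygen itself gave only the modest 2.4-fold lower number from compound 2 to compound 3 (0.38 log units; beyond the scatter) and the chain swap a 1.3-fold lower number from compound 1 to compound 2 (0.10 log units; within the scatter) stayed within the scatter, so among these compounds the large lowering appears only with phenyl on that chain carbon. No available data explain this lowering.

Open, from the compounds shown here alone, is whether a longer chain ending in phenyl keeps the lowering. Also open, going by these compounds, is how an amine or a carboxylic acid on that phenyl would shift the number.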